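Swapping chloro for trifluoromethoxy on a weak antiproliferative

The source may report more compounds than this note shows. Statements on the series, on what has been measured and on what is new or still open speak of the compounds shown alone.

Of the compounds shown here, two from this series have been tested for their effect on the growth of a human colon cancer cell line. Compound 1, with the structure `Nc1ccccc1NC(=O)/C=C/c1ccc(Cn2cnc3c(Nc4cccc(Cl)c4)nc(Cl)nc32)cc1`, carries a chloro group on the aniline ring that hangs from the shared core. In a functional assay on HCT-116 cells (Homo sapiens) for antiproliferative activity, read by CCK-8 assay, with a stated time of 72 h, tested at 2 uM (on this read-out higher numbers stand for a stronger effect at the one concentration tested and lower numbers for a weaker effect), compound 1 gives 12.9%. Compound 2, with the structure `COC(CCn1cnc2c(NCc3ccc(C(=O)Nc4ccccc4N)cc3)nc(Cl)nc21)OC`, gives 6.39% in this assay. The gap between these two numbers lies within the scatter of repeated measurements, so the two compounds cannot be told apart on this read-out, and both sit at the low end of what the assay can show.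

Compound 3, with the structure `Nc1ccccc1NC(=O)/C=C/c1ccc(Cn2cnc3c(Nc4cccc(OC(F)(F)F)c4)nc(Cl)nc32)cc1`, has not yet been measured. It differs from compound 1 in one place: trifluoromethoxy in place of chloro on an aromatic carbon. Among the measured compounds shown here, no measured pair in this set shows such a change, so there is no direct precedent for its effect. With both measured compounds weak, the expected step from compound 1 to compound 3 is small, in either direction, and likely no larger than the scatter: a number 2.1 percentage points higher from compound 1 to compound 3 (within the scatter). Compound 3 is therefore estimated at 15%, within a range from 2% to 35%.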

Compound 3, a percentage reported as inhibition, at one concentration (the size of the read-out at that concentration, not a potency): 2.8%
Compound 3: the middle estimate sits 12.2 percentage points above what was measured; the measured number falls inside the stated range.
By their numbers in this assay, from the lowest: compounds 3, 2 and 1 (each within the scatter of the next, the first and the last beyond it).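

Among the compounds shown here, the change from chloro to trifluoromethoxy gives the first step in this set that can be read for a single change: in this assay it is a number 10.1 percentage points lower from compound 1 to compound 3 (beyond the scatter) and counts as modest. The position on the aromatic ring, meta to a large group, therefore responds to what is placed there, and of these two groups chloro goes with the higher number, although both numbers remain low. Nothing at hand explains why the number falls with this change.

Still open, on these data alone, is how other groups would fare at this position, such as fluoro, methoxy (trifluoromethoxy without its fluorines), an amine, or plain hydrogen, and so whether the fall belongs to trifluoromethoxy alone or to any replacement of chloro. A single step at one concentration also leaves open whether the same swap would give a similar change elsewhere on the molecule, or how the two compounds would compare in potency across a range of concentrations.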